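The compounds below may be only part of what the source reports. "The series", "measured", "known", "first", "only" and "open" are said of these compounds alone.

Three compounds share one core and are compared in a functional assay on cells (Cancer cell lines, Homo sapiens) for inhibition; a lower number here means a stronger inhibitor of growth, a higher number a weaker inhibitor of growth. Compound 1 `N=C(N)N/N=C/c1c(-c2cccs2)nc2n1CCS2` gives 36300 nM, compound 2 `Cc1cc(-c2nc3n(c2/C=N/NC(=N)N)CCS3)c(C)s1` gives 30900 nM, and compound 3 `N=C(N)N/N=C/c1c(-c2ccsc2)nc2sccn12` gives 28800 nM. Compound 3 has the lowest of the three numbers, yet its gaps to compound 2 and to compound 1 both lie within the scatter, so no ranking can be drawn. For the measured compounds named here, the single measured step, a 1.2-fold lower number from compound 1 to compound 2 (0.07 log units; within the scatter), swapped in 2,5-dimethylthiophen-3-yl for thiophen-2-yl and also stayed within the scatter. Compound 4 `Cc1cn2c(/C=N/NC(=N)N)c(-c3ccsc3)nc2s1` differs from compound 3 by methyl in place of hydrogen on an aromatic carbon. Going by the values given here, only that step from compound 1 to compound 2 bears on adding methyl groups, and it was small, so the expected step is a 1.0-fold lower number from compound 3 to compound 4 (0.01 log units; within the scatter). Compound 4 is therefore estimated at 28000 nM, within 14000 nM to 56000 nM.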

Compound 4, concentration for total growth inhibition: 20000 nM
Compound 4: the middle estimate sits 1.4-fold (0.15 log units) above what was measured, and the stated range covers the measured number.
By their numbers in this assay, from the lowest: compounds 4, 3, 2 and 1 (each within the scatter of the next).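

Methyl in place of hydrogen on this aromatic carbon, next to the ring sulfur, gives a 1.4-fold lower number from compound 3 to compound 4 (0.16 log units; within the scatter) in this assay, so compound 3 and compound 4 cannot be told apart. The earlier step concerned the thiophene group, whereas this one sits on the shared core itself, and methyl at this position leaves the result within the scatter. Nothing available offers an explanation for this result. As far as these compounds go, whether an ethyl chain, an amine or a carboxylic acid at this carbon would move the number beyond the scatter remains open.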